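Series notes: compound 3 to compound 4

The source may report more compounds than this note shows. Statements on the series, on what has been measured and on what is new or still open speak of the compounds shown alone.

Measured compounds:
compound 1 `CCOC(=O)Cn1ncc2c(C)ncn2c1=O`, > 48000 nM
compound 2 `CCCc1nc(C)c2cnn(CC)c(=O)n12`, > 48000 nM
compound 3 `CCCc1nc(C)c2cnn(CC(=O)OCC)c(=O)n12`, > 48000 nM

In a functional assay for inhibition, with Homo sapiens as the target (a higher number here means a weaker inhibitor, a lower number a stronger inhibitor), compound 3 reports only a limit, > 48000 nM. Compound 1 likewise gives a limit. Compound 2 also gives a limit. Compound 4 `CCCc1nc(C)c2cnn(CC(O)CO)c(=O)n12` is not yet measured. The change is 1,2-dihydroxyethyl in place of ethoxycarbonyl on a saturated chain carbon bound to an aromatic nitrogen. The two steps that touch this position, a step that the two limits leave unreadable from compound 1 to compound 3 and a step that the two limits leave unreadable from compound 2 to compound 3, are both unreadable, because of the limit of > 48000 nM in this assay, at which 3 of the 3 values shown sit. No measured step can be read for size, so no direction is expected beyond the scatter, and compound 4 is expected to remain at or near that limit. The estimate for compound 4 in this assay is 60000 nM, with a range of 15000 nM to 200000 nM, meaning an expected step that the limit leaves unreadable from compound 3 to compound 4.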

Compound 4, half-maximal inhibitory concentration: > 48000 nM
Compound 4 gave a limit, no number; the forecaster's own chance of this, stated with the estimate: 80%; the middle value is on the limit's open side.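

In this assay no new step can be read from compound 4 to compound 2 or compound 3, because each comparison ends at the same limit: the limit of > 48000 nM in this assay, at which 4 of the 4 values shown sit. The compounds shown leave open whether any substituent at this place gives a readable inhibitory value.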